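From 3,4-difluorophenyl to 2,4-dichlorophenyl at the assay limit

The compounds below may be only part of what the source reports. "The series", "measured", "known", "first", "only" and "open" are said of these compounds alone.

Measured in a functional assay on MDA-MB-231 cells (Homo sapiens) for antiproliferative activity, read by MTT assay, with a stated time of 72 h; on this read-out lower numbers stand for stronger inhibition and higher numbers for weaker inhibition:
- compound 1 `CN(C)CCn1cnnc1-c1cc(Oc2ccc(NC(=O)Nc3cccc(C(F)(F)F)c3)cc2F)ccn1`: 16400 nM
- compound 2 `CN(C)CCn1cnnc1-c1cc(Oc2ccc(NC(=O)Nc3ccccc3C(F)(F)F)cc2F)ccn1`: > 50000 nM (a limit of the assay)
- compound 3 `CN(C)CCn1cnnc1-c1cc(Oc2ccc(NC(=O)Nc3ccc(F)c(F)c3)cc2F)ccn1`: > 50000 nM (a limit of the assay)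

Compound 3 has no number, only a limit, and it stands at the limit of > 50000 nM in this assay, at which 2 of the 3 values shown sit. Its neighbour compound 4 `CN(C)CCn1cnnc1-c1cc(Oc2ccc(NC(=O)Nc3ccc(Cl)cc3Cl)cc2F)ccn1` differs by 2,4-dichlorophenyl in place of 3,4-difluorophenyl on an amide-type nitrogen, which is 2,4-dichlorophenyl in place of 3,4-difluorophenyl on an amide-type nitrogen. Two measured changes at that same place bear on this: an at least 3.0-fold higher number from compound 1 to compound 2 (0.48 log units; beyond the scatter) and an at least 3.0-fold higher number from compound 1 to compound 3 (0.48 log units; beyond the scatter). Both lead to weaker inhibition once the 3-(trifluoromethyl)phenyl of compound 1 is gone, and compound 4 lacks that group too. The remaining change, a step that the two limits leave unreadable from compound 2 to compound 3, gives no size to work with. Compound 4 is therefore expected to stay weak, with little or no real gain over the limit. The expected step, which can only be roughly estimated, is an at least 1.1-fold lower number from compound 3 to compound 4 (0.04 log units; that floor lies within the scatter) in this assay and may not be readable at all. Compound 4 is estimated at 45000 nM, within an expected range of 15000 nM to 80000 nM.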

Compound 4, half-maximal inhibitory concentration: 7960 nM
Estimate against measurement, compound 4: 5.7-fold (0.75 log units) above; the whole stated range lies above it.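

In this assay, the group on the amide-type nitrogen can give up the 3-(trifluoromethyl)phenyl of compound 1 and still gain, as 2,4-dichlorophenyl gives a 2.1-fold lower number from compound 1 to compound 4 (0.31 log units; beyond the scatter). On these data alone, the same group also clears the limit reached with the other two replacements, giving an at least 6.2-fold lower number from compound 3 to compound 4 (0.79 log units; beyond the scatter) and an at least 6.2-fold lower number from compound 2 to compound 4 (0.79 log units; beyond the scatter), and both of these steps are floors whose true size stays unknown. Compounds 2 and 3 remain limits rather than numbers, so losing the 3-(trifluoromethyl)phenyl does not by itself cost activity at this place: the limit of > 50000 nM in this assay, at which 2 of the 4 values shown sit.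

The compounds shown leave open whether a phenyl ring bearing a single chlorine would keep the gain, or whether both chlorines are needed. They also leave open whether bromine or methoxy could take the place of chlorine.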